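From 4-methoxyphenyl to 2-fluorophenyl at a limit

The compounds below may be only part of what the source reports. "The series", "measured", "known", "first", "only" and "open" are said of these compounds alone.

Measured in an ADME assay on HCT-116 cells (Homo sapiens) for cytotoxicity, read by CellTiter-Glo, with a stated time of 72 h; a higher number here means a weaker inhibitor, a lower number a stronger inhibitor:
Compound 1 `CC1CCN(C2CCN(S(=O)(=O)c3cccc(N)c3)CC2)CC1`: > 5000 nM (a limit)
Compound 2 `COc1ccc(-c2cccc(S(=O)(=O)N3CCC(N4CCC(C)CC4)CC3)c2)cc1`: > 5000 nM (a limit)

Compound 2 has no exact number in this assay, because its result of > 5000 nM is a limit of the assay. Compound 1 also has only a limit, > 5000 nM. Taken together, the evidence so far is the limit of > 5000 nM in this assay, at which 2 of the 2 values shown sit.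

Compound 3 `CC1CCN(C2CCN(S(=O)(=O)c3cccc(-c4ccccc4F)c3)CC2)CC1` has not yet been measured. It differs from compound 2 by a single change: 2-fluorophenyl in place of 4-methoxyphenyl on an aromatic carbon.

For the measured compounds named here, the only measured step that bears on this change is a step that the two limits leave unreadable from compound 1 to compound 2. It offers no size to carry over, and it gives no direction either. The expectation therefore rests on compound 2, whose only reading is the limit > 5000 nM. The expected step is a step that the limit leaves unreadable from compound 2 to compound 3, with nothing beyond the usual scatter anticipated. For compound 3 the estimate is 6000 nM, with an expected range of 2500 nM to 12000 nM, and the assay is expected to report only a limit.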

Compound 3, half-maximal inhibitory concentration: > 5000 nM
Compound 3 ended at the assay's limit; the forecaster's own chance of this, stated with the estimate: 75%; the middle value is on the limit's open side.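

For the compounds shown here, compound 1, compound 2 and compound 3 all give only a limit, so no step between them can be read in this assay: the limit of > 5000 nM in this assay, at which 3 of the 3 values shown sit. The compounds shown leave open whether amino, 4-methoxyphenyl and 2-fluorophenyl differ at all in this assay, and what exact number any of these three compounds would have.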